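The compounds below may be only part of what the source reports. "The series", "measured", "known", "first", "only" and "open" are said of these compounds alone.

Compound 1 `CC(C)(C)OC(=O)N1C[C@@H](n2cc(-c3ccc4c(N)n[nH]c4c3)nn2)C[C@H]1C(=O)Nc1ccc(Cl)c(C(F)(F)F)c1` gives 37.1% in a functional assay on K562/Adr cells (Homo sapiens) for inhibition, read by MTT assay, with a stated time of 48 h, tested at 30 uM; on this read-out lower numbers stand for less inhibition and higher numbers for more inhibition at the one concentration tested (going by the name of the read-out).
Compound 2 `Nc1n[nH]c2cc(-c3cn([C@@H]4CN[C@H](C(=O)Nc5ccc(Cl)c(C(F)(F)F)c5)C4)nn3)ccc12` gives 48.2%.
Compound 3 `CC(C)(C)OC(=O)N1C[C@@H](n2cc(-c3ccc4nc(N)sc4n3)nn2)C[C@H]1C(=O)Nc1ccc(Cl)cc1Cl` gives 28.3%.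

Compound 2 arises from compound 1 by one change, (hydrogen in place of tert-butoxycarbonyl on an amine nitrogen in a ring), and the measured step is a number 11.1 percentage points higher from compound 1 to compound 2 (beyond the scatter). Compound 4 `Nc1nc2ccc(-c3cn([C@@H]4CN[C@H](C(=O)Nc5ccc(Cl)cc5Cl)C4)nn3)nc2s1` has not been measured yet. It arises from compound 3 by the same kind of change, (hydrogen in place of tert-butoxycarbonyl on an amine nitrogen in a ring); the surroundings are not identical, since in compound 1 the change sits next to the ring atom that bears a large group, whereas in compound 3 it sits next to the ring atom that bears a (2,4-dichlorophenyl)carbamoyl group. How the core of compound 1 and the core of compound 3 differ is not broken down here. For compound 4 a step of about a number 10.7 percentage points higher from compound 3 to compound 4 (beyond the scatter) in this assay is expected, because the earlier step was a number 11.1 percentage points higher from compound 1 to compound 2 (beyond the scatter). Compound 4 is therefore estimated at 39%, within 25% to 55%.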

Compound 4, a percentage reported as inhibition, at one concentration (the size of the read-out at that concentration, not a potency): 42.2%
Beside the measured number, compound 4's estimate is 3.2 percentage points below it; measured number inside the range.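

In this assay, putting hydrogen in place of tert-butoxycarbonyl on the ring nitrogen gives a number 13.9 percentage points higher from compound 3 to compound 4 (beyond the scatter), so the change carried over to the second core with much the same size: the same change on two cores in this assay, a number 11.1 percentage points higher (beyond the scatter) from compound 1 to compound 2 and a number 13.9 percentage points higher (beyond the scatter) from compound 3 to compound 4, 2.8 percentage points apart, within the scatter of two such steps. Within these two pairs of compounds, the step can therefore be carried from one core to the other. It does not show that the step would hold on any further core, and it does not explain why the number rises, while a reading at one concentration says nothing about potency.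

Only tert-butoxycarbonyl and hydrogen appear on that ring nitrogen here. On these data alone, how an acetyl group or a methyl group in the same place would read remains open.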